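Chloro for Fluoro on the Aryl Ring: Compound 4

The compounds below may be only part of what the source reports. "The series", "measured", "known", "first", "only" and "open" are said of these compounds alone.

Compound 1 `CC(C(=O)N1CCN(c2ccccc2)CC1)N1C(=O)CCC1=O`: 50%
Compound 2 `CCC(C(=O)N1CCN(c2cccc(F)c2)CC1)N1C(=O)CCC1=O`: 100%
Compound 3 `CC(C(=O)N1CCN(c2cccc(F)c2)CC1)N1C(=O)CCC1=O`: 50%

Three compounds share a core in which a succinimide-bearing side chain is linked through a carbonyl to an arylpiperazine. In a functional assay on the whole organism (strain Swiss) with Mus musculus as the target, in the maximal electroshock model, with a stated time of 0.5 h, at a dose of 300 mg/kg by the intraperitoneal route (on this read-out lower numbers stand for a weaker effect and higher numbers for a stronger effect at the one dose given), compound 1 gives 50%, compound 2 gives 100% and compound 3 gives 50%. Compound 3 stands level with compound 1, the two together being the lowest of the three numbers, and it lies furthest from compound 2. The step of no change at the digits printed from compound 1 to compound 3 (within the scatter) shows that a fluoro in place of hydrogen on an aromatic carbon left the read-out unchanged, whereas a number 50 percentage points lower from compound 2 to compound 3 (beyond the scatter), a hydrogen in place of methyl on a saturated chain carbon, was a large drop.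

Compound 4 `CC(C(=O)N1CCN(c2cccc(Cl)c2)CC1)N1C(=O)CCC1=O` is the next member: chloro in place of fluoro on an aromatic carbon, so that the 3-fluorophenyl of compound 3 becomes a 3-chlorophenyl. Among the compounds with values here, no measured step exchanges one halogen for another on this ring. Within the data shown here, the only step on that aromatic carbon, no change at the digits printed from compound 1 to compound 3 (within the scatter), was within the scatter, which gives a weak hint that what sits there matters little, but with one such step the expectation is uncertain. Compound 4 is therefore expected to show no change at the digits printed from compound 3 to compound 4 (within the scatter) in this assay, with an estimated value of 50% and a range from 25% to 75%.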

Compound 4, a percentage reported as activity, at one dose (the size of the read-out at that dose, not a potency): 100%
For compound 4 the middle estimate is 50 percentage points below the measured one; the measured number lies above the stated range.
By their numbers in this assay, from the lowest: compounds 1 and 3 (each within the scatter of the next); then compounds 2 and 4 (each within the scatter of the next).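

In this assay, within the data shown here, the halogen on this aromatic carbon turns out to matter, with chloro in place of fluoro giving the step (a number 50 percentage points higher from compound 3 to compound 4 (beyond the scatter)), something the one earlier step at this carbon (no change at the digits printed from compound 1 to compound 3 (within the scatter)) gave no sign of. Chloro in place of hydrogen on the same carbon also gives a large step (a number 50 percentage points higher from compound 1 to compound 4 (beyond the scatter)), so this position responds to which group enters and not merely to a hydrogen being replaced, and a step of this size is no longer confined to the saturated chain carbon (a number 50 percentage points lower from compound 2 to compound 3 (beyond the scatter)). Nothing available here explains why chloro and fluoro part ways at this position.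

The compounds shown leave open whether bromo, methoxy or trifluoromethyl on this aromatic carbon would read like chloro or like fluoro, and whether chloro elsewhere on the ring would give the same result. They also leave open what chloro would do alongside the longer chain of compound 2, and how the 3-chlorophenyl and 3-fluorophenyl compounds would compare at other doses or times.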